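A few compounds are considered here, and "the series" means these few. Any claim that something is new, unique, unknown or untested is made for them only; others in the source may bear on it.

Measured compounds:
Compound 1, `Cc1ccc(-n2cc(CNC(=O)c3cccc4c3cnn4C(C)C)nn2)c(C)c1`: > 40000 nM
Compound 2, `CC(C)n1ncc2c(C(=O)NCc3cn(-c4ccc(F)cc4)nn3)cccc21`: > 40000 nM
Compound 3, `CC(C)n1ncc2c(C(=O)NCc3cn(-c4ccccc4F)nn3)cccc21`: > 40000 nM

In a functional assay on HepG2 cells (Homo sapiens) for inhibition, read by MTT assay, with a stated time of 72 h (on this read-out higher numbers stand for weaker inhibition and lower numbers for stronger inhibition), compound 1 reaches only a limit, > 40000 nM. Compound 2 likewise stands at the limit > 40000 nM in this assay. Compound 3, the starting point of the step followed here, also gives only the limit > 40000 nM. Thus compound 3 stands at a limit rather than at a number, as the summary shows: the limit of > 40000 nM in this assay, at which 3 of the 3 values shown sit. The steps from compound 1 to compound 2, a step that the two limits leave unreadable from compound 1 to compound 2, from compound 1 to compound 3, a step that the two limits leave unreadable from compound 1 to compound 3, and from compound 2 to compound 3, a step that the two limits leave unreadable from compound 2 to compound 3, all join two limits and so give no readable size. Compound 4, `CC(C)n1ncc2c(C(=O)NCc3cn(Cc4ccccc4)nn3)cccc21`, differs from compound 3 by benzyl in place of 2-fluorophenyl on an aromatic nitrogen. Every measured step concerns a change of the group on this same aromatic nitrogen, and none of them moved a compound off the limit. Compound 4 is therefore expected to remain at the limit, with an estimate of 45000 nM and a range from 15000 nM to 150000 nM. The expected step from compound 3 to compound 4 is a step that the limit leaves unreadable from compound 3 to compound 4, that is, no change that could be read.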

Compound 4, half-maximal inhibitory concentration: 13700 nM
Estimate against measurement, compound 4: 3.3-fold (0.52 log units) above; measured number outside the range, below it.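

In this assay, the group on this aromatic nitrogen can take a compound off the limit, something compound 1, compound 2 and compound 3 could not show, as the steps among those three cannot be read. Benzyl in place of the directly attached rings gives an at least 2.9-fold lower number from compound 3 to compound 4 (0.46 log units; beyond the scatter), an at least 2.9-fold lower number from compound 2 to compound 4 (0.46 log units; beyond the scatter) and an at least 2.9-fold lower number from compound 1 to compound 4 (0.46 log units; beyond the scatter), and each size is only a minimum, as each step starts from a limit. Among the compounds shown, only compound 4 has a number rather than a limit: the limit of > 40000 nM in this assay, at which 3 of the 4 values shown sit.

On these data alone, the full size of these steps stays open. As far as these compounds go, it is also open whether a longer chain such as phenethyl, a benzyl carrying fluorine, or a benzyl carrying an amine on this nitrogen would lower the number further.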